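This account rests on a few compounds, and the source may have more. Where it says the series, first, only, none or still open, it means among the compounds named here.

Of the compounds shown here, three have been measured in a functional assay on HCT-116 cells (Homo sapiens) for cytotoxicity, read by MTT assay, with a stated time of 48 h; a lower number here means a stronger inhibitor, a higher number a weaker inhibitor. Compound 1, `CN(C)CCNc1ccnc2cc(OCc3ccc(F)cc3)ccc12`, gives 370 nM. Compound 3, `CN(C)CCNc1ccnc2cc(OCc3ccccc3)ccc12`, gives 1980 nM. Compound 2, `CC(C)COc1ccc2c(Cl)ccnc2c1`, gives 2490 nM. On these numbers compound 2 stands highest of the three: its number sits within the scatter of that of compound 3, and only its gap to compound 1 lies beyond the scatter. Among the compounds with values here, the single step between measured compounds that differ in one place is a 5.4-fold higher number from compound 1 to compound 3 (0.73 log units; beyond the scatter), hydrogen in place of fluoro on an aromatic carbon.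

Compound 4, `CCCCCCOc1ccc2c(Cl)ccnc2c1`, shares the core of compound 2 and differs from it in one place: pentyl in place of isopropyl on a saturated chain carbon bound to an oxygen on an aromatic ring. Within the data shown here, the one measured step concerns a different pair of compounds and a different kind of group, so nothing measured here bears on a change in the length of this chain. Without such a guide, a step in this assay beyond the scatter is not expected in either direction, though the range around the estimate is kept wide. For compound 4 the expectation is therefore 2200 nM, with a range from 700 nM to 7000 nM. That means an expected step of a 1.1-fold lower number from compound 2 to compound 4 (0.05 log units; within the scatter).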

Compound 4, half-maximal inhibitory concentration: 2440 nM
Compound 4: the middle estimate sits 1.1-fold (0.04 log units) below what was measured; the range from low to high includes it.
By their numbers in this assay, from the lowest: compound 1; then compounds 3, 4 and 2 (each within the scatter of the next).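

In this assay, pentyl in place of isopropyl on a saturated chain carbon bound to an oxygen on an aromatic ring gives a 1.0-fold lower number from compound 2 to compound 4 (0.01 log units; within the scatter), which lies within the usual scatter of repeated measurements. Within the data shown here, this is the first measured pair that speaks to this position, and it shows that these two chains, read one bond further out as isobutyl and hexyl, cannot be told apart in this test, even though the entering group carries more carbon atoms than the one that leaves. Nothing available here offers an explanation for this result.

From the compounds shown here alone, a single pair covers only two chains, so it remains open whether the same would hold for a much longer chain, or for a chain ending in an amine or a carboxylic acid at this place. Going by these compounds, it is also open whether fluoro, whose replacement by hydrogen gives a 5.4-fold higher number from compound 1 to compound 3 (0.73 log units; beyond the scatter) in another pair, would matter on a compound with the core shared by compound 2 and compound 4.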